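The source may report more compounds than this note shows. Statements on the series, on what has been measured and on what is new or still open speak of the compounds shown alone.

Measured so far in an assay on cells for agonist activity at ecdysone receptor (Bombyx mori), read by a luciferase reporter, with a stated time of 24 h; a lower number here means that less compound is needed, a higher number that more compound is needed for the effect:
- compound 1 `CC(C)(C)N(NC(=O)c1cccc(C#N)c1)C(=O)c1ccccc1Cl`: 955 nM
- compound 2 `CCc1ccc(C(=O)NN(C(=O)c2ccccc2Cl)C(C)(C)C)cc1`: 5.75 nM

Among the compounds with values here, of these two numbers, compound 2 holds the lower one; the single measured step, a 170-fold lower number from compound 1 to compound 2 (2.22 log units; beyond the scatter), shows how strongly the aromatic ring on that carbonyl carbon can move the result. Compound 3 `CC(C)(C)N(NC(=O)c1cccc(Cl)c1Cl)C(=O)c1ccccc1Cl` is the next change at the same position: 2,3-dichlorophenyl in place of 4-ethylphenyl on a carbonyl carbon. Within the data shown here, the only step that bears on it is the one from compound 1 to compound 2, which was large, so a new ring at this carbonyl carbon can be expected to shift the number well beyond the scatter. Because the 4-ethylphenyl of compound 2 gave 5.75 nM while the 3-cyanophenyl of compound 1 gave 955 nM, removing the 4-ethylphenyl is expected to raise the number. For compound 3 the estimate in this assay is 300 nM, with a range from 40 nM to 2500 nM, which is expected to mean a 52-fold higher number from compound 2 to compound 3 (1.72 log units; beyond the scatter).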

Compound 3, half-maximal effective concentration: 9.33 nM
Estimate against measurement, compound 3: 32-fold (1.51 log units) above; measured number outside the range, below it.
By their numbers in this assay, from the lowest: compounds 2 and 3 (each within the scatter of the next); then compound 1.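

In this assay the change to 2,3-dichlorophenyl gives a 1.6-fold higher number from compound 2 to compound 3 (0.21 log units; within the scatter) and so shows that a low number at this carbonyl carbon does not require the 4-ethylphenyl, since a ring with two chlorines and no ethyl chain does just as well. Within the data shown here, replacing the 3-cyanophenyl with the same ring gives a 100-fold lower number from compound 1 to compound 3 (2.01 log units; beyond the scatter) and so repeats the large drop first seen with the 4-ethylphenyl, which leaves compound 1 as the one compound of the three standing apart. Nothing measured here explains these results.

The compounds shown leave open whether a ring carrying an amine or a carboxylic acid, or a plain phenyl with no added group, would keep the number this low. Nor do they tell whether the nitrile itself or its place on the ring sets compound 1 apart.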